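Triazine series: isopropoxy for fluoro on the aryl ring

The compounds below may be only part of what the source reports. "The series", "measured", "known", "first", "only" and "open" are said of these compounds alone.

Of the compounds shown here, three have been measured in a functional assay on cells for positive allosteric modulation of G-protein coupled receptor 68 (Homo sapiens), read by a luciferase reporter and cAMP accumulation, with a stated time of 30 min, at pH 6.8 and pH 8.3, in the presence of a further agent that is not named here; a higher number here means a more potent compound, by a factor of ten per unit of this negative logarithm, a lower number a less potent compound. Compound 1 `Nc1nc(NCc2ccccc2)nc(-c2cccc(F)c2CO)n1` gives 4.01. Compound 2 `Nc1nc(NCc2ccccc2)nc(-c2ccc(F)cc2CO)n1` gives 4.58, the highest of the three numbers. Compound 3 `Nc1nc(NCc2ccccc2)nc(-c2cc(Cl)ccc2CO)n1` gives 4.49, which lies within the scatter of compound 2, so no order between these two can be claimed. Compound 1 sits beyond the scatter below compound 2. For the measured compounds named here, no pair among the measured compounds differs in a single place, so no isolated step is available.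

Compound 4 `CC(C)Oc1ccc(-c2nc(N)nc(NCc3ccccc3)n2)c(CO)c1` has not been measured. It differs from compound 2 by isopropoxy in place of fluoro on an aromatic carbon. Going by the values given here, nothing among the measured compounds tells how a change at this position behaves, so the expectation rests on compound 2 alone. A modest step in the upward direction is expected for compound 4, written as a number 0.32 log units higher from compound 2 to compound 4 (beyond the scatter), though a result within the scatter of compound 2 would not be surprising. For compound 4 the estimated value in this assay is 4.9, with a range from 4.3 to 5.4.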

Compound 4, negative logarithm of the antagonist equilibrium constant: 4.91
Compound 4: the middle estimate sits 0.01 log units below what was measured, within the range that was stated.
By their numbers in this assay, from the lowest: compound 1; then compounds 3 and 2 (each within the scatter of the next); then compound 4.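

Isopropoxy in place of fluoro on this aromatic carbon, meta to a hydroxymethyl group and para to a large group, gives a number 0.33 log units higher from compound 2 to compound 4 (beyond the scatter) in this assay and is the only single-place step among the compounds shown. The position therefore accepts isopropoxy, a group of 4 heavy atoms, with no loss in this read-out. No measurement shown bears on why the number rises.

Only one replacement at this position is shown, so it remains open whether the rise follows the oxygen on the ring or the size of the alkyl part. Methoxy, a longer alkoxy chain or an amine on this same carbon would help separate those two readings.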